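From chloro to ethyl in a growth inhibitor

The source may report more compounds than this note shows. Statements on the series, on what has been measured and on what is new or still open speak of the compounds shown alone.

Compound 1 `COc1ccc(Cn2nc(Br)c3c(NC(=O)c4csc5c(N)ncnc45)cccc32)cc1`: 2390 nM
Compound 2 `Cc1cccc(Cn2nc(Cl)c3c(NC(=O)c4csc5c(N)ncnc45)cccc32)n1`: 8 nM

In a functional assay on NFS-60 cells (Mus musculus) for inhibition, with a stated time of 72 h (a lower number here means a stronger inhibitor of growth, a higher number a weaker inhibitor of growth), compound 2 gives 8 nM, the lower of the two numbers, while compound 1 gives 2390 nM. That gap lies well beyond the usual scatter. The two compounds differ in more than one place, so their values cannot be tied to any single change.

Compound 3 `CCc1nn(Cc2cccc(C)n2)c2cccc(NC(=O)c3csc4c(N)ncnc34)c12` follows from compound 2 with one change: ethyl in place of chloro on an aromatic carbon. That carbon belongs to a five-membered aromatic ring with 2 nitrogen, part of a fused system of two rings. Among the measured compounds shown here, no measured pair shows this swap, so the size of the step in this assay can only be judged loosely. The expectation starts from compound 2 at 8 nM and allows for a modest weakening of growth inhibition, possibly no more than the scatter. The expected change is a 2.5-fold higher number from compound 2 to compound 3 (0.40 log units; beyond the scatter). For compound 3 the estimated value is 20 nM, with an expected range of 5 nM to 80 nM.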

Compound 3, concentration for 50% growth inhibition: > 10000 nM
Compound 3 gave a limit, no number; the forecaster's own chance of this, stated with the estimate: 2%; middle value at least 500-fold (2.69 log units) from the limit.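

In this assay compound 3 gives > 10000 nM, which is a limit of the assay and not a number. Ethyl in place of chloro on an aromatic carbon of the five-membered aromatic ring gives an at least 1200-fold higher number from compound 2 to compound 3 (3.09 log units; beyond the scatter), the first step here that can be tied to one place, and it shows that growth inhibition in this series depends strongly on what stands at this carbon: a swap of one small group for another, with the rest of compound 2 kept, is enough to lose it in this assay. The comparison of compound 1 with compound 2 could not show this, and the step itself is only a lower bound, with its full size unread: the limit of > 10000 nM in this assay, at which 1 of the 3 values shown sits.

The compounds shown leave open whether a methyl or a nitrile at this carbon would keep the growth inhibition of compound 2 or lose it as ethyl does. Compound 1 and compound 2 differ in more than one place, so the effect of bromo at this carbon also stays unread.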